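Allyl in Place of Ethoxycarbonyl on a Shared Core

The source may report more compounds than this note shows. Statements on the series, on what has been measured and on what is new or still open speak of the compounds shown alone.

Measured compounds:
Compound 1, `CCOC(=O)C(Cc1cccc(OCC(=O)O)c1)c1nc(-c2ccccc2)c(-c2ccccc2)o1`: 120 nM
Compound 2, `CS(=O)(=O)C(Cc1cccc(OCC(=O)O)c1)c1nc(-c2ccccc2)c(-c2ccccc2)o1`: 7960 nM
Compound 3, `CC(C)C(Cc1cccc(OCC(=O)O)c1)c1nc(-c2ccccc2)c(-c2ccccc2)o1`: 970 nM

In a functional assay for inhibition, with Homo sapiens as the target (on this read-out lower numbers stand for stronger inhibition and higher numbers for weaker inhibition), compound 1 gives 120 nM, the lowest number among the three measured compounds. Compound 3 comes nearest, and the step of an 8.1-fold higher number from compound 1 to compound 3 (0.91 log units; beyond the scatter) is modest. Compound 2 lies furthest away, and the step of a 66-fold higher number from compound 1 to compound 2 (1.82 log units; beyond the scatter) is large. Between the two substitutes, the step of an 8.2-fold lower number from compound 2 to compound 3 (0.91 log units; beyond the scatter) shows that isopropyl gives a distinctly lower number than methylsulfonyl.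

Compound 4, `C=CCC(Cc1cccc(OCC(=O)O)c1)c1nc(-c2ccccc2)c(-c2ccccc2)o1`, has not yet been measured. It differs from compound 1 as follows: allyl in place of ethoxycarbonyl on a saturated chain carbon bound to an aromatic carbon and a saturated chain carbon. Going by the values given here, the step that bears most directly on this change is the one to compound 3, where isopropyl replaced ethoxycarbonyl at the same place and the number rose by an 8.1-fold higher number from compound 1 to compound 3 (0.91 log units; beyond the scatter). Allyl, like isopropyl, is a short chain of three carbon atoms, so a rise of similar size is expected in this assay. Compound 4 is therefore expected to show a step of a 6.7-fold higher number from compound 1 to compound 4 (0.82 log units; beyond the scatter), with an estimate of 800 nM and a range from 250 nM to 3000 nM.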

Compound 4, half-maximal inhibitory concentration: 570 nM
The estimate for compound 4 lay 1.4-fold (0.15 log units) above the measured number; low and high end bracket the measured number.
By their numbers in this assay, from the lowest: compound 1; then compounds 4 and 3 (each within the scatter of the next); then compound 2.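

In this assay the step of a 1.7-fold lower number from compound 3 to compound 4 (0.23 log units; within the scatter) does not separate allyl from isopropyl at this saturated chain carbon. The step of a 4.8-fold higher number from compound 1 to compound 4 (0.68 log units; beyond the scatter) shows that allyl does not hold the number of compound 1, even though it keeps one double bond outside aromatic rings as ethoxycarbonyl does; what leaves with this change are the two oxygen atoms and the two hydrogen-bond acceptors. The step of a 14-fold lower number from compound 2 to compound 4 (1.15 log units; beyond the scatter) shows that allyl, like isopropyl, stays well clear of methylsulfonyl, so at this position the two carbon-only groups share a middle place in the series.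

From the compounds shown here alone, whether an amide or a longer ester chain at this place would come back to the number of compound 1 stays open. Nothing measured here gives a reason for these differences.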